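The source may report more compounds than this note shows. Statements on the series, on what has been measured and on what is new or still open speak of the compounds shown alone.

Measured compounds in an ADME assay on HepG2 cells (Homo sapiens) for cytotoxicity, read by luminescence, CellTiter-Glo and ATP content, with a stated time of 72 h; on this read-out lower numbers stand for an effect already at smaller amounts and higher numbers for an effect only at larger amounts of compound:
compound 1, `COc1cccc(CNCCCNc2ccnc3cc(-c4ccc(C(C)(C)C)cc4)ccc23)c1O`, compound 1 gives 690 nM
compound 2, `CC(C)(C)c1ccc(-c2ccc3c(NCCCNCc4ccco4)ccnc3c2)cc1`, compound 2 gives 3150 nM
compound 3, `COc1ccc(F)cc1CNCCCNc1ccnc2cc(-c3ccc(C(C)(C)C)cc3)ccc12`, compound 3 gives 620 nM

Compound 2 stands at the highest number of the three: the step is a 4.6-fold higher number from compound 1 to compound 2 (0.66 log units; beyond the scatter), and the step is a 5.1-fold lower number from compound 2 to compound 3 (0.71 log units; beyond the scatter), both beyond the scatter, while compound 1 and compound 3 sit within the scatter of each other (a 1.1-fold lower number from compound 1 to compound 3 (0.05 log units; within the scatter)).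

Compound 4, `N#Cc1ccc(Cc2ccc3c(NCCCNCc4ccco4)ccnc3c2)cc1`, differs from compound 2 in one place: 4-cyanobenzyl in place of 4-(tert-butyl)phenyl on an aromatic carbon.

Every measured step changes the group on the saturated chain carbon bound to an amine nitrogen, and none changes the group on the aromatic carbon of the fused two-ring core. So no measured step bears directly on this change, and the only guide is the range the three measured numbers span. The expectation for compound 4 is therefore a wide one, centred a little above compound 2, with the step from compound 2 expected to be a 1.6-fold higher number from compound 2 to compound 4 (0.20 log units; within the scatter). Compound 4 is estimated at 5000 nM, with a range from 1500 nM to 20000 nM.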

Compound 4, half-maximal effective concentration: 7910 nM
For compound 4 the middle estimate is 1.6-fold (0.20 log units) below the measured one; the measured number falls inside the stated range.
By their numbers in this assay, from the lowest: compounds 3 and 1 (each within the scatter of the next); then compound 2; then compound 4.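

Going by these compounds alone, this is the first measured change on the aromatic carbon of the shared core, and in this assay it shows that this position also affects the number, with 4-cyanobenzyl in place of 4-(tert-butyl)phenyl giving a 2.5-fold higher number from compound 2 to compound 4 (0.40 log units; beyond the scatter) as a modest step beyond the scatter. The swap changes several things at once, since the entering group is a benzyl rather than a phenyl, carries a nitrile and has one hydrogen-bond acceptor, so this single step cannot separate their contributions. No measurement here explains the rise.

Plain benzyl or 4-(tert-butyl)benzyl at this position would help separate the benzyl link from the nitrile and the tert-butyl group. From the compounds shown here alone, it also remains open whether the step would look the same with 5-fluoro-2-methoxyphenyl in place of furan-2-yl on the chain.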